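Swapping an Iodine-Bearing Ring for a Methyl-Bearing One

A few compounds are considered here, and "the series" means these few. Any claim that something is new, unique, unknown or untested is made for them only; others in the source may bear on it.

Compound 1, `COC(=O)C1=C(C)N=C(C)/C(=C(\O)OC)C1c1ccccc1I`, gives 46.8 nM.
Compound 2, `COC(=O)C1=C(C)N=C(C)/C(=C(\O)OC)C1c1cccc(Cl)c1Cl`, gives 19.1 nM.
Compound 3, `COC(=O)C1=C(C)N=C(C)/C(=C(\O)OC)C1c1cccc(I)c1`, gives 41.7 nM.

These three compounds share one core and differ only in the aromatic ring attached on a saturated ring carbon. All were tested in a functional assay (muscle tissue) with Cavia porcellus as the target; on this read-out lower numbers stand for an effect already at smaller amounts and higher numbers for an effect only at larger amounts of compound. Compound 3 stands second highest of the three numbers. The step of a 1.1-fold lower number from compound 1 to compound 3 (0.05 log units; within the scatter) lies within the scatter, so compound 1 and compound 3 cannot be told apart, whereas a 2.2-fold higher number from compound 2 to compound 3 (0.34 log units; beyond the scatter) lies beyond it, and a 2.5-fold lower number from compound 1 to compound 2 (0.39 log units; beyond the scatter) points the same way.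

Compound 4, `COC(=O)C1=C(C)N=C(C)/C(=C(\O)OC)C1c1ccccc1C`, has not yet been measured. (2-methylphenyl in place of 3-iodophenyl on a saturated ring carbon). Among the compounds with values here, no measured step exchanges a halogen for a methyl group, so none bears on this change directly. The nearest guide is that shifting the iodine around the ring, or replacing it by two chlorines, moved this assay only modestly. For the methyl-bearing ring a small rise in the number is therefore expected, roughly a 1.7-fold higher number from compound 3 to compound 4 (0.22 log units; within the scatter), though a result within the scatter would not surprise. Compound 4 is estimated at 70 nM, with a range from 25 nM to 200 nM.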

Compound 4, half-maximal effective concentration: 6.03 nM
Beside the measured number, compound 4's estimate is 12-fold (1.06 log units) above it, and the stated range ends above it.
By their numbers in this assay, from the lowest: compound 4; then compound 2; then compounds 3 and 1 (each within the scatter of the next).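

In this assay, the first three compounds sat fairly close together, so the aromatic ring on the saturated ring carbon looked like a place where changes did little, yet 2-methylphenyl gives a 6.9-fold lower number from compound 3 to compound 4 (0.84 log units; beyond the scatter) and a 3.2-fold lower number from compound 2 to compound 4 (0.50 log units; beyond the scatter), leaving compound 4 with the lowest number of the four. Within the data shown here, the most direct comparison keeps the rest of the ring unchanged and exchanges only one group, methyl in place of iodo on an aromatic carbon, and it gives a 7.8-fold lower number from compound 1 to compound 4 (0.89 log units; beyond the scatter), a far clearer shift than moving the iodine around the ring, which gave only a 1.1-fold lower number from compound 1 to compound 3 (0.05 log units; within the scatter). Nothing available here explains why this exchange lowers the number so much.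

Still open, from the compounds shown here alone, is whether the lower number is specific to methyl, or whether an ethyl, methoxy or trifluoromethyl group in the same place would lower it further or bring it back up. Also open, going by these compounds, is whether a methyl group would have the same effect at the place the iodine holds in compound 3, and whether a second methyl group on the ring would add to it.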